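The source may hold more compounds than are shown below. What is called first, only, known or untested is meant among the compounds shown, and "the series" means these compounds.

Working notes on the series. In an ADME assay on Vero cells (Chlorocebus sabaeus) for cytotoxicity, read by flow cytometry and propidium iodide staining, with a stated time of 72 h (on this read-out higher numbers stand for weaker inhibition and lower numbers for stronger inhibition), compound 1 (`Cn1nc(OCc2ccccc2)c2cc([N+](=O)[O-])ccc21`) gives 194000 nM and compound 2 (`COc1nn(CCOCCN)c2ccc([N+](=O)[O-])cc12`) gives 87200 nM as the lower of the two numbers, with the gap between them beyond the scatter. The next step leads to compound 3 (`COc1nn(C)c2ccc([N+](=O)[O-])cc12`) and reads hydrogen in place of (2-aminoethoxy)methyl on a saturated chain carbon bound to an aromatic nitrogen in the structure: hydrogen in place of (2-aminoethoxy)methyl on a saturated chain carbon bound to an aromatic nitrogen. Within the data shown here, no measured pair isolates this change. Among the measured compounds shown here, compound 1, which also lacks the 2-(2-aminoethoxy)ethyl chain, stands at 194000 nM and is the only guide. A moderate rise in the number is therefore expected in this assay and would mean weaker inhibition. The estimated shift is a 2.1-fold higher number from compound 2 to compound 3 (0.31 log units; beyond the scatter) in that upward direction. For compound 3 the expected value is 180000 nM (estimated range 70000 nM to 450000 nM).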

Compound 3, half-maximal inhibitory concentration: 183000 nM
For compound 3 the middle estimate is 1.0-fold (0.01 log units) below the measured one, and the stated range covers the measured number.
By their numbers in this assay, from the lowest: compound 2; then compounds 3 and 1 (each within the scatter of the next).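

In this assay, the change from 2-(2-aminoethoxy)ethyl to methyl now stands alone, and a 2.1-fold higher number from compound 2 to compound 3 (0.32 log units; beyond the scatter) ties the lower number of compound 2 in this pair to that chain. The second single change, hydrogen in place of phenyl on a saturated chain carbon bound to an oxygen on an aromatic ring, gives a 1.1-fold lower number from compound 1 to compound 3 (0.03 log units; within the scatter) and so leaves the number within the scatter. Nothing measured here bears on the reason for either step.

Still open, on these data alone, is whether a shorter 2-aminoethyl chain, or a chain ending in a hydroxyl group in place of the amine, would keep the number of compound 2. Also open, as far as these compounds go, is how a carboxylic acid in place of the phenyl would read on that saturated chain carbon.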